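The compounds below may be only part of what the source reports. "The series", "measured", "known", "first", "only" and "open" are said of these compounds alone.

Compounds measured in a functional assay on the whole organism with Rattus norvegicus as the target, at a dose of 100 mg/kg; a lower number here means less inhibition, a higher number more inhibition at the dose given (going by the name of the read-out): compound 1 `C=CCNC(=S)NCCCCn1nc(-c2ccccc2)ccc1=O` gives 27.1%; compound 2 `C/N=C(/NC#N)N(C)CCCCn1nc(-c2ccccc2)ccc1=O` gives 27%.

In this assay compound 2 stands lowest of the two numbers, with compound 1 nearest to it, the two lying within the scatter of each other. Compound 3 `C/N=C(\S)NCCCCCCn1nc(-c2ccccc2)ccc1=O` differs from compound 2 by a group of 7 heavy atoms (4 carbon, 2 nitrogen, 1 sulfur; no ring) in place of a group of 8 heavy atoms (4 carbon, 4 nitrogen; no ring), on a saturated chain carbon, four bonds along the chain from an aromatic nitrogen. Within the data shown here, the one step that bears on this is the exchange at the same place between compound 1 and compound 2, which gave a number 0.1 percentage points lower from compound 1 to compound 2 (within the scatter). No step beyond the scatter is therefore expected, and compound 3 is estimated at 27% (range 15% to 39%), a step of no change at the digits printed from compound 2 to compound 3 (within the scatter).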

Compound 3, a percentage reported as inhibition, in the whole organism at one dose (the size of the read-out at that dose, not a potency): 22.2%
Beside the measured number, compound 3's estimate is 4.8 percentage points above it; the range from low to high includes it.
By their numbers in this assay, from the lowest: compounds 3, 2 and 1 (each within the scatter of the next).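

In this assay the read-out stays within the scatter across a third group at this place, on a saturated chain carbon, four bonds along the chain from an aromatic nitrogen: the exchange gives a number 4.8 percentage points lower from compound 2 to compound 3 (within the scatter) and also a number 4.9 percentage points lower from compound 1 to compound 3 (within the scatter) without any step beyond the scatter. Swapping the group with a triple bond and 1 hydrogen-bond donor for the sulfur-bearing group with 2 hydrogen-bond donors therefore separates nothing here. No measurement offered here explains this result. As far as these compounds go, whether a primary amine or a carboxylic acid at this place would move the number remains open.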